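Adding a Methoxy to a Dimethoxyphenyl Triazole Amide

This account rests on a few compounds, and the source may have more. Where it says the series, first, only, none or still open, it means among the compounds named here.

Compound 1 `O=C(NCc1cn(Cc2ccc(Cl)cc2)nn1)c1cn(-c2ccccc2)nc1-c1ccc(F)cc1` gives 130 nM in a functional assay on MCF7 cells (Homo sapiens) for antiproliferative activity, read by sulforhodamine B assay, with a stated time of 48 h (on this read-out higher numbers stand for weaker inhibition of growth and lower numbers for stronger inhibition of growth), and compound 2 `COc1cc(Cn2cc(CNC(=O)c3cn(-c4ccccc4)nc3-c3ccc(F)cc3)nn2)cc(OC)c1` gives 2500 nM in this assay, the higher of the two numbers; the change is a 19-fold higher number from compound 1 to compound 2 (1.28 log units; beyond the scatter). Compound 3 `COc1cc(Cn2cc(CNC(=O)c3cn(-c4ccccc4)nc3-c3ccc(F)cc3)nn2)cc(OC)c1OC` differs from compound 2 by methoxy in place of hydrogen on an aromatic carbon. Among the compounds with values here, no measured step concerns adding a methoxy group; the single step only exchanged one aryl group for another, so it gives little guidance. Compound 3 is therefore expected to stay near compound 2, with the step of a 1.4-fold lower number from compound 2 to compound 3 (0.14 log units; within the scatter) estimated within the scatter. The estimate for compound 3 is 1800 nM, ranging from 400 nM to 8000 nM.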

Compound 3, concentration for 50% growth inhibition: 4300 nM
The estimate for compound 3 lay 2.4-fold (0.38 log units) below the measured number; the measured number falls inside the stated range.
By their numbers in this assay, from the lowest: compound 1; then compounds 2 and 3 (each within the scatter of the next).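

In this assay the methoxy entering the ring that already carries two methoxy groups gives a 1.7-fold higher number from compound 2 to compound 3 (0.24 log units; within the scatter) and so separates the two compounds no more than repeat measurements would. The distance from the 4-chlorophenyl compound remains large, with a 33-fold higher number from compound 1 to compound 3 (1.52 log units; beyond the scatter) on the change to 3,4,5-trimethoxyphenyl. No evidence is available to explain either step.

On these data alone, whether a single methoxy or a fluorine on this ring would stay near compound 1 or near compound 3 remains open. So does the effect of an amine or a carboxylic acid at this place.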